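The source may hold more compounds than are shown below. What is called first, only, known or untested is meant among the compounds shown, and "the series" means these compounds.

In a functional assay on PC-3 cells (Homo sapiens) for antiproliferative activity, read by MTT assay, with a stated time of 48 h (a lower number here means a stronger inhibitor, a higher number a weaker inhibitor), two compounds with a shared core have been measured. Compound 1 (`CCn1c(C(=O)NCCCN(C)C)ccc1C(CC)(CC)c1ccc(OCCC(O)(CC)CC)c(C)c1`) gives 2150 nM as its half-maximal inhibitory concentration, and compound 2 (`CCn1c(C(=O)N(C)CCO)ccc1C(CC)(CC)c1ccc(OCCC(O)(CC)CC)c(C)c1`) gives 3090 nM on the same core. Compound 2 therefore stands level with compound 1, as the two numbers lie within the scatter of repeated measurements.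

Compound 3 (`CCn1c(C(=O)NC(C)CO)ccc1C(CC)(CC)c1ccc(OCCC(O)(CC)CC)c(C)c1`) keeps that core and carries (1-(hydroxymethyl)ethyl)amino in place of (2-hydroxyethyl)(methyl)amino on a carbonyl carbon, so the atoms stay the same but are joined differently. For the measured compounds named here, the one measured step that bears on this change is a 1.4-fold higher number from compound 1 to compound 2 (0.16 log units; within the scatter) at that same carbonyl carbon. It shows no change beyond the scatter, although a single step is thin evidence. In this assay no step beyond the scatter is therefore expected, in either direction. The estimate is a 1.0-fold lower number from compound 2 to compound 3 (0.01 log units; within the scatter) and so amounts to no expected change. Compound 3 is estimated at 3000 nM with 1400 nM to 6500 nM as the expected range.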

Compound 3, half-maximal inhibitory concentration: 7870 nM
Estimate against measurement, compound 3: 2.6-fold (0.42 log units) below; measured number above the stated range.
By their numbers in this assay, from the lowest: compounds 1 and 2 (each within the scatter of the next); then compound 3.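

In this assay, the group on this carbonyl carbon turns out to matter more than the earlier pair suggested: (1-(hydroxymethyl)ethyl)amino in place of (2-hydroxyethyl)(methyl)amino gives a 2.5-fold higher number from compound 2 to compound 3 (0.41 log units; beyond the scatter) even though the atoms are the same and only their joining differs. The other comparison points the same way, with 1-(hydroxymethyl)ethyl in place of 3-(dimethylamino)propyl on the amide-type nitrogen giving a 3.7-fold higher number from compound 1 to compound 3 (0.56 log units; beyond the scatter) in this small set. No measurement shown here accounts for this shift.

For the compounds shown here, the single change from compound 2 to compound 3 does several things at once: the methyl leaves the nitrogen, an amide hydrogen appears, the count rises from 1 to 2 hydrogen-bond donors, and the chain becomes branched, so these compounds cannot tell which of these matters. A plain (2-hydroxyethyl)amino group on the same carbonyl carbon, which has the amide hydrogen but no branch, would help pull these apart, and a longer chain ending in a hydroxyl group remains an open question as well.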